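The source may hold more compounds than are shown below. What is called first, only, known or untested is meant among the compounds shown, and "the series" means these compounds.

Measured in a functional assay on MCF7 cells (Homo sapiens) for inhibition, read by MTT assay, with a stated time of 72 h; a lower number here means a stronger inhibitor, a higher number a weaker inhibitor:
Compound 1 `COc1cc(NC(C)CCCNC(=O)NNC(=O)Nc2ccc(Cl)cc2)c2ncccc2c1` gives 180 nM
Compound 2 `COc1cc(NC(C)CCCNC(=O)Nc2ccc(F)cc2)c2ncccc2c1` gives 26000 nM
Compound 3 `COc1cc(NC(C)CCCNC(=O)Nc2cccc(O)c2)c2ncccc2c1` gives 11000 nM

Compound 3 holds the middle of these three numbers, lying close to compound 2 and far from compound 1, the most potent of the set. The next compound, compound 4 `COc1cc(NC(C)CCCNC(=O)Nc2ccc(C(F)(F)F)cc2)c2ncccc2c1`, differs from compound 3 by 4-(trifluoromethyl)phenyl in place of 3-hydroxyphenyl on an amide-type nitrogen; in words, this is 4-(trifluoromethyl)phenyl in place of 3-hydroxyphenyl on an amide-type nitrogen.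

Within the data shown here, the closest guide is the one measured exchange of one phenyl group for another at this place, a 2.4-fold lower number from compound 2 to compound 3 (0.37 log units; beyond the scatter), a modest step. The far larger steps, a 140-fold higher number from compound 1 to compound 2 (2.16 log units; beyond the scatter) and a 61-fold higher number from compound 1 to compound 3 (1.79 log units; beyond the scatter), both involve the loss of the ((4-chlorophenyl)carbamoyl)amino group. Compound 4 lacks that group too, so these steps suggest it will stay with the two weaker compounds and not approach compound 1. Among the measured compounds shown here, no compound carrying trifluoromethyl has been measured, so the direction remains uncertain. The expected change is a 1.3-fold higher number from compound 3 to compound 4 (0.10 log units; within the scatter), which is not expected to go clearly beyond the scatter. In this assay compound 4 is estimated at 14000 nM, with an expected range from 5000 nM to 40000 nM.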

Compound 4, half-maximal inhibitory concentration: 1900 nM
Estimate against measurement, compound 4: 7.4-fold (0.87 log units) above, outside the stated range (below it).
By their numbers in this assay, from the lowest: compound 1; then compound 4; then compound 3; then compound 2.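

Among these compounds, the position on the amide-type nitrogen proved more responsive than the one earlier exchange of phenyl groups had suggested: in this assay, the change to 4-(trifluoromethyl)phenyl gave a 5.8-fold lower number from compound 3 to compound 4 (0.76 log units; beyond the scatter), well beyond the step seen between the 4-fluorophenyl and 3-hydroxyphenyl compounds. The clearest comparison changes only the group on the aromatic carbon, and there the exchange of fluoro for trifluoromethyl gave a 14-fold lower number from compound 2 to compound 4 (1.14 log units; beyond the scatter), so loss of the ((4-chlorophenyl)carbamoyl)amino group does not by itself fix a compound at the weak end of the series. That group still marks the strongest compound here, since replacing it with 4-(trifluoromethyl)phenyl gave an 11-fold higher number from compound 1 to compound 4 (1.02 log units; beyond the scatter), although this gap is narrower than those to compound 2 and compound 3.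

No measurement shown here explains why these numbers move as they do. From the compounds shown here alone, it remains open how a 4-chlorophenyl group placed directly on the amide-type nitrogen, or a phenyl group carrying a nitrile or a carboxylic acid, would compare with compound 4, and whether trifluoromethyl in place of the chlorine of compound 1 would bring any further change.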